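From hydroxy to (4-methylpiperazin-1-yl)methyl on the side chain

This account rests on a few compounds, and the source may have more. Where it says the series, first, only, none or still open, it means among the compounds named here.

In an assay on isolated protein for inhibition of ATP-dependent RNA helicase DDX3X (Homo sapiens), read by FRET, with stated times of 30 s and 40 min (on this read-out lower numbers stand for stronger inhibition and higher numbers for weaker inhibition), compound 2 `Cc1ccccc1NC(=O)Nc1ccc(-n2cc(CCO)nn2)cc1` gives 13000 nM, the highest number of the three measured compounds. Compound 3 `O=C(Nc1ccc(-n2cc(CCO)nn2)cc1)Nc1ccccc1C(F)(F)F` gives 11200 nM, and compound 1 `COCCc1cn(-c2ccc(NC(=O)Nc3ccccc3C)cc2)nn1` gives 1000 nM. Compound 4 `Cc1ccccc1NC(=O)Nc1ccc(-n2cc(CCCN3CCN(C)CC3)nn2)cc1` differs from compound 2 by (4-methylpiperazin-1-yl)methyl in place of hydroxy on a saturated chain carbon, two bonds along the chain from an aromatic carbon. The step of a 1.2-fold lower number from compound 2 to compound 3 (0.06 log units; within the scatter) alters another part of the molecule and does not bear on this. The step of a 13-fold higher number from compound 1 to compound 2 (1.11 log units; beyond the scatter) does bear on it, since it shows that changing the end of this chain moves the number strongly and that the hydroxy of compound 2 goes with the higher number. For the measured compounds named here, removing that hydroxy is therefore expected to lower the number, although the entering group has no measured precedent, so compound 4 is estimated at 2500 nM (range 600 nM to 10000 nM), an expected step of a 5.2-fold lower number from compound 2 to compound 4 (0.72 log units; beyond the scatter).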

Compound 4, half-maximal inhibitory concentration: 40100 nM
Estimate against measurement, compound 4: 16-fold (1.21 log units) below; measured number outside the range, above it.
By their numbers in this assay, from the lowest: compound 1; then compounds 3 and 2 (each within the scatter of the next); then compound 4.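

In this assay the 3-(4-methylpiperazin-1-yl)propyl chain end brings a 3.1-fold higher number from compound 2 to compound 4 (0.49 log units; beyond the scatter) and a 40-fold higher number from compound 1 to compound 4 (1.60 log units; beyond the scatter) so losing the hydroxy does not by itself give a lower number. What replaces the hydroxy decides the direction: among compounds 1, 2 and 4, which differ only at this chain end, the number can move either way from the hydroxy. Nothing measured here explains the rise seen with compound 4.

Still open, from the compounds shown here alone, is how a shorter amine such as dimethylamino would behave at this chain end. Also open, going by these compounds, is whether an ethoxy group or a longer chain ending in methoxy would match or improve on the methoxy of compound 1.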